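Trimethoxyphenyl series: indol-3-yl against 3-methylphenyl

This account rests on a few compounds, and the source may have more. Where it says the series, first, only, none or still open, it means among the compounds named here.

Measured so far:
compound 1 `COc1cc(-c2ccnc3cc(-c4c[nH]c5ccccc45)nn23)cc(OC)c1OC` — 40 nM
compound 2 `COc1cc(-c2ccnc3cc(-c4cn(C(=O)OC(C)(C)C)c5ccccc45)nn23)cc(OC)c1OC` — 3070 nM

In a functional assay on B16-F0 cells (Mus musculus) for inhibition, read by CCK-8 assay, with a stated time of 48 h (on this read-out lower numbers stand for stronger inhibition and higher numbers for weaker inhibition), compound 1 gives the lowest of the two numbers; its nearest neighbour is compound 2, reached by a 77-fold higher number from compound 1 to compound 2 (1.89 log units; beyond the scatter). Compound 3 `COc1cc(-c2ccnc3cc(-c4cccc(C)c4)nn23)cc(OC)c1OC` differs from compound 1 by 3-methylphenyl in place of 1H-indol-3-yl on an aromatic carbon. Going by the values given here, the single measured step touches the indole nitrogen only and bears on this change indirectly; it shows that alterations at the indol-3-yl group can cost much. The step to compound 3 is therefore expected to weaken inhibition, a 7.5-fold higher number from compound 1 to compound 3 (0.88 log units; beyond the scatter), with wide uncertainty. Compound 3 is estimated at 300 nM, range 60 nM to 2000 nM.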

Compound 3, half-maximal inhibitory concentration: 2220 nM
For compound 3 the middle estimate is 7.4-fold (0.87 log units) below the measured one, outside the stated range (above it).
By their numbers in this assay, from the lowest: compound 1; then compounds 3 and 2 (each within the scatter of the next).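

In this assay, exchange of the whole group on the aromatic carbon gives a 56-fold higher number from compound 1 to compound 3 (1.74 log units; beyond the scatter), so a large loss is no longer confined to substitution on the indole nitrogen. The entering 3-methylphenyl keeps a six-membered aromatic ring of carbon only but lacks the five-membered aromatic ring and the hydrogen-bond donor, and this single step does not separate those differences. No independent evidence bears on the cause of the loss.

Open, as far as these compounds go, is whether a phenyl carrying an amine or a hydroxyl in place of methyl would restore inhibition. Also open, from the compounds shown here alone, is how a methyl on the indole nitrogen would compare.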